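The compounds below may be only part of what the source reports. "The series", "measured", "known", "first", "only" and "open" are said of these compounds alone.

Compound 1, `COc1cc2ncnc(NCc3cccc(NC(=O)Nc4ccccc4)c3)c2cc1OC`, in a functional assay on HepG2 cells (Homo sapiens) for antiproliferative activity, read by MTT assay (on this read-out lower numbers stand for stronger inhibition and higher numbers for weaker inhibition), gives 19700 nM.
Compound 2, `COc1ccc(NC(=O)Nc2cccc(CNc3ncnc4cc(OC)c(OC)cc34)c2)cc1`, in this assay gives only a limit of the assay, > 50000 nM.

Compound 2 therefore stands at the weak end of the numbers shown; its value is a limit rather than a number, and one of the two values sits at that limit (the limit of > 50000 nM in this assay, at which 1 of the 2 values shown sits). Compound 3, `COc1cc2ncnc(NCc3cccc(NC(=O)Nc4ccc(C(C)(C)C)cc4)c3)c2cc1OC`, differs from compound 2 by tert-butyl in place of methoxy on an aromatic carbon. Going by the values given here, only one measured step touches this part of the molecule, the change from hydrogen to methoxy, an at least 2.5-fold higher number from compound 1 to compound 2 (0.40 log units; beyond the scatter), which went toward weaker inhibition. Among the compounds with values here, no measured step covers a tert-butyl group at this place, so the direction for compound 3 remains open. Compound 3 is expected to shift by an at least 1.2-fold lower number from compound 2 to compound 3 (0.09 log units; that floor lies within the scatter), with a real chance that the assay again reports only a limit. The estimate for compound 3 is 40000 nM, between 10000 nM and 150000 nM.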

Compound 3, half-maximal inhibitory concentration: 6850 nM
The estimate for compound 3 lay 5.8-fold (0.77 log units) above the measured number, outside the stated range (below it).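

The position on this six-membered aromatic ring of carbon only is not closed to substitution: tert-butyl in place of hydrogen gives a 2.9-fold lower number from compound 1 to compound 3 (0.46 log units; beyond the scatter), toward stronger inhibition in this assay, whereas methoxy had gone the other way. The direction of change at this place therefore depends on the group that stands there, and the exchange of methoxy for tert-butyl gives an at least 7.2-fold lower number from compound 2 to compound 3 (0.86 log units; beyond the scatter). The value of compound 2 in that step is only a limit: the limit of > 50000 nM in this assay, at which 1 of the 3 values shown sits.

From the compounds shown here alone, whether an amine, a carboxylic acid or a longer chain at this place would follow tert-butyl or methoxy remains open. It is also open whether tert-butyl would give a shift in the same direction on another carbon of this ring, or with a core other than the shared core of these compounds.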